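A few compounds are considered here, and "the series" means these few. Any claim that something is new, unique, unknown or untested is made for them only; others in the source may bear on it.

Working notes on a set of succinimide-bearing amides tested in a functional assay on the whole organism (strain Swiss) with Mus musculus as the target, in the maximal electroshock model, with a stated time of 1 h, at a dose of 300 mg/kg by the intraperitoneal route; a higher number here means a stronger effect of the compound at the dose given, a lower number a weaker effect. Three compounds have numbers. Compound 1 `COCC(C(=O)N1CCN(c2cccc(C(F)(F)F)c2)CC1)N1C(=O)CCC1=O` gives 100% in this assay. Compound 2 `CC(C(=O)N1CCN(c2ccccc2)CC1)N1C(=O)CCC1=O` gives 50%, and compound 3 `CCC(C(=O)N1CCN(c2ccccc2Cl)CC1)N1C(=O)CCC1=O` gives 50%. On these numbers compound 2 stands level with compound 3 at the digits reported, within the scatter, so no order between the two can be read; together they are the lowest of the three. Against compound 1 the gap from compound 2 lies beyond the scatter, so compound 1 is the stronger of that pair at the dose given.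

The step under study leads from compound 2 to compound 4 `CC(C(=O)N1CCN(c2ccccc2F)CC1)N1C(=O)CCC1=O`, which is not yet measured in this assay. The change is fluoro in place of hydrogen on an aromatic carbon of a six-membered aromatic ring of carbon only, ortho to a large group. Within the data shown here, no step between measured compounds isolates this change. Compound 3 carries a different halogen at the same kind of position and its value in this assay does not differ from compound 2 within the scatter, though compound 3 also differs in the chain.

The step from compound 2 to compound 4 is therefore expected to be small, a number 5 percentage points higher from compound 2 to compound 4 (within the scatter), not beyond the scatter in either direction. For compound 4 the expected value in this assay is 55%, with a range from 25% to 85%.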

Compound 4, a percentage reported as activity, at one dose (the size of the read-out at that dose, not a potency): 50%
Estimate against measurement, compound 4: 5 percentage points above; low and high end bracket the measured number.
By their numbers in this assay, from the lowest: compounds 2, 3 and 4 (each within the scatter of the next); then compound 1.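

In this assay fluoro in place of hydrogen on an aromatic carbon, ortho to a large group, gives no change at the digits printed from compound 2 to compound 4 (within the scatter) and so turns phenyl into 2-fluorophenyl with the rest of the molecule held constant. Among these compounds, this is the first step that isolates a change at this position, since compound 3 differs from compound 2 in the chain as well as in the ring substituent, and it shows that this single fluoro atom leaves the read-out at this dose within the scatter. No measurement at hand bears on why the number holds at this position.

The read-out is a single-dose percentage and so leaves open whether compound 2 and compound 4 would also match at lower doses, while a nitrile, an amine or a carboxylic acid at this same ring position remains unaddressed by the compounds shown. Compound 1 reaches 100% but differs from compound 2 and compound 4 in more than one place, so the part played by its trifluoromethyl group or its methoxymethyl chain stays unresolved.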